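Swapping the imidazole amide for a cyclohexyl amide

The source may report more compounds than this note shows. Statements on the series, on what has been measured and on what is new or still open speak of the compounds shown alone.

Compound 2 `Cn1c(-c2ccccc2)cnc1NC(=O)c1ncc[nH]1` shares its core with compound 1 `Cn1c(-c2ccc(C#N)cc2)cnc1NC(=O)c1ncc[nH]1` and compound 3 `COc1ccccc1-c1cnc(NC(=O)c2ncc[nH]2)n1C`. In a toxicity assay on THP-1 cells (Homo sapiens) for inhibition (on this read-out higher numbers stand for lower toxicity in this test and lower numbers for higher toxicity in this test), compound 2 is reported only as a limit, > 100000 nM. Compound 1 likewise returns a limit, > 100000 nM. Compound 3 also sits at a limit, > 50000 nM. The step that the two limits leave unreadable from compound 1 to compound 2 and the step that the two limits leave unreadable from compound 2 to compound 3 therefore cannot be read, since two of the three values rest on the limit of > 100000 nM in this assay, at which 2 of the 3 values shown sit, and one on (the limit of > 50000 nM in this assay, at which 1 of the 3 values shown sits). Compound 2 thus stands at a limit, not at a number.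

Compound 4 `Cn1c(-c2ccccc2)cnc1NC(=O)C1CCCCC1` differs from compound 2 in one place: cyclohexyl in place of 1H-imidazol-2-yl on a carbonyl carbon. Going by the values given here, the two measured steps alter only a substituent on an aromatic carbon of the core and are both unreadable in size, so no measured step bears on a change at the carbonyl carbon. The expected step of a number no higher from compound 2 to compound 4 (the limit leaves the size open) is accordingly one that cannot be set apart from the scatter. Compound 4 is estimated to give 100000 nM, within 30000 nM to 300000 nM, most likely reported once more as a limit.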

Compound 4, half-maximal cytotoxic concentration: > 100000 nM
Compound 4: no number, only a limit (the forecaster's own chance of this, stated with the estimate: 70%); the middle value lies on the limit itself.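

In this assay compound 4 gives > 100000 nM as a limit and not a number. With compound 2 also at a limit, the step between compound 2 and compound 4 cannot be read. In this assay the compounds shown leave open at what concentration any of them becomes toxic to the cells.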